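From ethoxy to methoxy in a cytotoxicity study

The source may hold more compounds than are shown below. What is called first, only, known or untested is meant among the compounds shown, and "the series" means these compounds.

Values measured in a functional assay on MCF7 cells (Homo sapiens) for cytotoxicity, read by MTT assay, with a stated time of 24 h (on this read-out higher numbers stand for weaker inhibition and lower numbers for stronger inhibition), are as follows
- compound 1 `C=C1C(=O)[C@@]23C[C@@H]1CC[C@@H]2[C@@]1(C)CCCC(C)(C)[C@@H]1COC3=O` gives 6600 nM as a number
- compound 2 `C=C1CC[C@H](C)[C@@](C)(CCC2=CC(OCC)OC2=O)C/C=C\C=C/1C(=O)O` gives > 40000 nM as a limit
- compound 3 `C[C@H]1CC[C@@]2(C)C(C(=O)O)=CCC[C@H]2[C@]1(C)CCC1=CCOC1=O` gives > 40000 nM as a limit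

Compound 2 stands at > 40000 nM as a limit of the assay and not as a number. Compound 3 also gives > 40000 nM as a limit. Only compound 1 gives a true number, at 6600 nM on the same scale.

Compound 4 `C=C1CC[C@H](C)[C@@](C)(CCC2=CC(OC)OC2=O)C/C=C\C=C/1C(=O)O` is not yet measured. It differs from compound 2 in one place, where ethoxy becomes methoxy: hydrogen in place of methyl on a saturated chain carbon bound to an oxygen on a saturated carbon with hydrogen in place of methyl on a saturated chain carbon bound to an oxygen on a saturated carbon.

Among the measured compounds shown here, no measured pair shows what this change does. The expectation in this assay is therefore no shift beyond the usual scatter in either direction, and it rests on compound 2 with its limit of > 40000 nM alone. The expected change is a step that the limit leaves unreadable from compound 2 to compound 4 as an estimate only. Compound 4 is estimated at 45000 nM with an expected range from 20000 nM to 90000 nM and may well come out only as a limit.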

Compound 4, half-maximal inhibitory concentration: > 40000 nM
Compound 4 gave a limit, no number; the forecaster's own chance of this, stated with the estimate: 80%; the middle value lies beyond the limit too.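

Compound 2 and compound 4 both give only a limit of the assay and not a number, so no step can be read between them because of where they sit: the limit of > 40000 nM in this assay, at which 3 of the 4 values shown sit.

On these data alone, whether the change from ethoxy to methoxy alters cytotoxicity at all remains open.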